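Swapping Cyclobutyl for Cyclopentyl on a Saturated Chain

This account rests on a few compounds, and the source may have more. Where it says the series, first, only, none or still open, it means among the compounds named here.

In an ADME assay on microsomes from liver (Homo sapiens) for metabolic stability, read by LC-MS, using NADPH, with a stated time of 45 min, tested at 3 uM (a higher number here means that the compound lasts longer, a lower number that the compound disappears faster), compound 1 (`C1CCC(CC(C2CCCC2)C2CC2)NC1`) gives 0.45 h as its half-life and compound 2 (`C1CCC(CC(C2CCCC2)C2CCC2)NC1`) gives 0.85 h as its half-life, so compound 2 stands within the usual scatter of compound 1 and the two cannot be told apart. Compound 3 (`C1CCC(CC(C2CCCC2)C2CCCC2)NC1`) has not yet been measured. It carries cyclopentyl in place of cyclobutyl on a saturated chain carbon bound to a saturated chain carbon and a saturated ring carbon. Within the data shown here, the one measured step that bears on this is the swap of cyclobutyl for cyclopropyl on that same carbon (a 1.9-fold higher number from compound 1 to compound 2 (0.28 log units; within the scatter)), which stays within the scatter. So in this assay no step beyond the scatter is expected, with an estimated move (a 1.3-fold higher number from compound 2 to compound 3 (0.11 log units; within the scatter)) that leans slightly upward. Compound 3 is expected to show a half-life near 1.1 h within an estimated range from 0.5 h to 2.4 h in this measurement.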

Compound 3, half-life: 0.833 h
Beside the measured number, compound 3's estimate is 1.3-fold (0.12 log units) above it; the range from low to high includes it.
By their numbers in this assay, from the lowest: compounds 1, 3 and 2 (each within the scatter of the next).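

In this assay, a third ring size at this place adds two new readings: cyclopentyl against cyclobutyl (a 1.0-fold lower number from compound 2 to compound 3 (0.01 log units; within the scatter)) and cyclopentyl against cyclopropyl (a 1.9-fold higher number from compound 1 to compound 3 (0.27 log units; within the scatter)). Both steps stay within the scatter, so cyclopropyl, cyclobutyl and cyclopentyl on this saturated chain carbon cannot be told apart, and the half-life shows no sign of following ring size among these three compounds. No supporting measurement is at hand to explain this result.

From the compounds shown here alone, it remains open whether a group of another kind on the same carbon, such as a phenyl ring, a ring carrying a hydroxyl group or an open isopropyl chain, would move the half-life beyond the scatter. Changes elsewhere on the shared core also remain open.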